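Cyclopropylmethyl to cyclobutylmethyl: working notes

The source may report more compounds than this note shows. Statements on the series, on what has been measured and on what is new or still open speak of the compounds shown alone.

Measured so far in an in vitro ADME assay on microsomes from liver (Homo sapiens) for metabolic stability, read by LC-MS, using NADPH, tested at 1 uM; a lower number here means that the compound disappears faster, a higher number that the compound lasts longer
- compound 1 `O=C1CN(Cc2ccc(-c3ccc(F)c(CN4CCCCC4)n3)cc2)C(=O)N1CC1CC1` gives 0.333 h
- compound 2 `O=C1CN(Cc2ccc(-c3cccc(CN4CCCCC4)n3)cc2)C(=O)N1C1CC1` gives 2 h

Compound 1 holds the lower of the two numbers, and compound 2 lies higher, beyond the scatter. Compound 3 `O=C1CN(Cc2ccc(-c3ccc(F)c(CN4CCCCC4)n3)cc2)C(=O)N1CC1CCC1` carries cyclobutyl in place of cyclopropyl on a saturated chain carbon bound to an amide-type nitrogen in a ring. Going by the values given here, no measured pair shows this change alone. As far as these compounds go, no step beyond the scatter is expected in this assay and the direction remains open, with a slight lean towards a lower number. The estimated step runs a 1.1-fold lower number from compound 1 to compound 3 (0.05 log units; within the scatter) and is expected to stay within the scatter. Compound 3 is estimated at 0.3 h (expected range 0.15 h to 0.6 h).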

Compound 3, half-life: 0.0833 h
The estimate for compound 3 lay 3.6-fold (0.56 log units) above the measured number; measured number below the stated range.
By their numbers in this assay, from the lowest: compound 3; then compound 1; then compound 2.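

In this assay, cyclobutyl in place of cyclopropyl on a saturated chain carbon bound to an amide-type nitrogen in a ring gives a 4.0-fold lower number from compound 1 to compound 3 (0.60 log units; beyond the scatter). Going by these compounds alone, this is the first single-place change, and it shows that the half-life responds to this position, with the rest of the structure held constant. No evidence on the cause of the step is available. As far as these compounds go, the step rests on one pair, so whether it carries over to the core of compound 2 stays open. From the compounds shown here alone, how a cyclopentylmethyl group or a methoxyethyl chain would read at this position also stays open.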